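The source may hold more compounds than are shown below. What is called first, only, known or untested is meant among the compounds shown, and "the series" means these compounds.

Compound 1 (`Cc1ccc(S(=O)(=O)n2cc(/C=C/C(=O)c3ccncc3)c3ccccc32)cc1`) was tested in an ADME assay on HEK293 cells (Homo sapiens) for antiproliferative activity, read by MTT assay, with a stated time of 48 h; a lower number here means a stronger inhibitor, a higher number a weaker inhibitor. There compound 1 gives > 150000 nM, which is a limit and not a number. Compound 2 (`CCCS(=O)(=O)n1cc(/C=C/C(=O)c2ccncc2)c2ccccc21`) gives > 150000 nM, also a limit. Compound 3 (`O=C(/C=C/c1cn(S(=O)(=O)c2ccc(Cl)cc2)c2ccccc12)c1ccncc1`) gives > 150000 nM, again a limit. The whole set therefore rests at one point: the limit of > 150000 nM in this assay, at which 3 of the 3 values shown sit.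

Compound 4 (`CC(C)(C)c1ccc(S(=O)(=O)n2cc(/C=C/C(=O)c3ccncc3)c3ccccc32)cc1`) carries tert-butyl in place of methyl on an aromatic carbon, para to a large group: tert-butyl in place of methyl on an aromatic carbon. The closest measured change is chloro in place of methyl on an aromatic carbon, which gives a step that the two limits leave unreadable from compound 1 to compound 3. The exchange of the whole sulfonyl substituent gives a step that the two limits leave unreadable from compound 1 to compound 2, and also a step that the two limits leave unreadable from compound 2 to compound 3. None of these steps has a readable size, so they offer no support for a shift in either direction in this assay. The expected step of a number no higher from compound 1 to compound 4 (the limit leaves the size open) therefore stays within the scatter. Compound 4 is estimated at about 150000 nM, with an expected range from 60000 nM to 300000 nM.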

Compound 4, half-maximal inhibitory concentration: > 150000 nM
Compound 4 was reported as a limit (the forecaster's own chance of this, stated with the estimate: 75%); the middle value lies on the limit itself.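

Compound 4 gives > 150000 nM, which is a limit, so the steps to it from compound 1, compound 2 and compound 3 cannot be read. The compounds shown leave open how these sulfonyl substituents would rank against one another in this assay.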